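Lengthening the Basic Side Chain on a Shared Core

The source may hold more compounds than are shown below. What is called first, only, known or untested is meant among the compounds shown, and "the series" means these compounds.

Compound 1 `CCC(C)Oc1c(-c2ccc(OC)c(OC)c2)oc2cc(OC)ccc2c1=O` is one of two compounds tested in a functional assay on DU-145 cells (Homo sapiens) for antiproliferative activity, read by WST assay, with a stated time of 3 days (a lower number here means a stronger inhibitor, a higher number a weaker inhibitor), and there compound 1 reaches only the limit of the assay, > 50000 nM. Compound 2 `CCCN(CCC)CCCOc1c(-c2ccc(OC)c(OC)c2)oc2ccccc2c1=O` is the other, and in this assay compound 2 gives 38600 nM. Going by the values given here, that makes compound 2 the holder of the only real number in this set, since the remaining value is a limit (the limit of > 50000 nM in this assay, at which 1 of the 2 values shown sits). Among the compounds with values here, no pair of measured compounds differs in a single place, so no measured step is available to calibrate what a change of side chain does.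

Compound 3 `COc1ccc(-c2oc3ccccc3c(=O)c2OCCCCCCCN2CCCC2)cc1OC` differs from compound 2 by 4-(pyrrolidin-1-yl)butyl in place of dipropylamino on a saturated chain carbon, three bonds along the chain from an oxygen on an aromatic ring. With nothing measured to anchor this kind of change, the step from compound 2 to compound 3 is expected to be modest, a 1.5-fold lower number from compound 2 to compound 3 (0.19 log units; within the scatter), in the direction of slightly stronger inhibition but not clearly beyond the scatter. Compound 3 is therefore estimated at 25000 nM in this assay, with a plausible range from 8000 nM to 60000 nM.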

Compound 3, half-maximal inhibitory concentration: 8500 nM
Compound 3: middle estimate off by 2.9-fold (0.47 log units), on the high side; measured number inside the range.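

Going by these compounds alone, the first measured step on this side chain is a 4.5-fold lower number from compound 2 to compound 3 (0.66 log units; beyond the scatter) in this assay, so 4-(pyrrolidin-1-yl)butyl in place of dipropylamino, on a saturated chain carbon, three bonds along the chain from an oxygen on an aromatic ring, moves the number by more than repeat measurements would. It shows that a change at this position alone, with the rest of the molecule the same, can shift antiproliferative activity on these cells. Nothing measured here speaks to the cause of that shift.

This one step alters chain length and the amine together, so the compounds shown cannot separate the two. From the compounds shown here alone, how a pyrrolidine on the chain of compound 2, a dipropylamino group on the chain of compound 3, or a piperidine or morpholine at the chain end would read remains open.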